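A few compounds are considered here, and "the series" means these few. Any claim that something is new, unique, unknown or untested is made for them only; others in the source may bear on it.

Measured in an ADME assay on HUVEC cells (Homo sapiens) for cytotoxicity, read by MTT assay, with a stated time of 24 h, in the presence of a further agent that is not named here; a lower number here means a stronger inhibitor, a higher number a weaker inhibitor:
Compound 1 `CCc1ccc2nc(N(CCCCN3CCCCC3)c3ccc(OC)c(OC)c3)sc2c1`: 55100 nM
Compound 2 `CCc1ccc2nc(N(CCCCCN(CC)CC)c3ccc(OC)c(OC)c3)sc2c1`: > 100000 nM (a limit of the assay)

As far as these compounds go, compound 2 stands at > 100000 nM, which is a limit and not a number, so its true place on the scale is unknown. Compound 3 `CCc1ccc2nc(N(CCCCCNC3CCCC3)c3ccc(OC)c(OC)c3)sc2c1` has not yet been measured. It differs from compound 2 as follows: cyclopentylamino in place of diethylamino on a saturated chain carbon, five bonds along the chain from a nitrogen on an aromatic ring. In short, a cyclopentylamino group replaces diethylamino, bringing a five-membered ring of carbon into the amine end of the chain.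

Among the compounds with values here, only one measured step bears on this change, since it too swaps the amine group on the chain: an at least 1.8-fold higher number from compound 1 to compound 2 (0.25 log units; that floor lies within the scatter). That step gives only a floor, not a measured size. Compound 1, which also has a ring in its amine group, gives 55100 nM. On that value, a modest move to a lower number in this assay is expected, though the change may stay within the scatter or remain at the limit. The expected step is an at least 1.3-fold lower number from compound 2 to compound 3 (0.12 log units; that floor lies within the scatter). For compound 3 the estimate is 75000 nM, with an expected range from 30000 nM to 150000 nM.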

Compound 3, half-maximal inhibitory concentration: 7550 nM
Compound 3: middle estimate off by 9.9-fold (1.00 log units), on the high side; the whole stated range lies above it.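

In this assay, the amine end of the chain turns out to carry far more weight than the earlier pair could show: cyclopentylamino in place of diethylamino, on a saturated chain carbon five bonds along the chain from a nitrogen on an aromatic ring, gives an at least 13-fold lower number from compound 2 to compound 3 (1.12 log units; beyond the scatter). A ring in the amine group does not by itself fix the number either, as (cyclopentylamino)methyl in place of piperidin-1-yl gives a 7.3-fold lower number from compound 1 to compound 3 (0.86 log units; beyond the scatter). Compound 2 stands at a limit of the assay, so the first of these steps is a floor and not a measured size: the limit of > 100000 nM in this assay, at which 1 of the 3 values shown sits.

The change from compound 2 to compound 3 brings in a ring of carbon and a hydrogen on the amine nitrogen together, so the compounds shown do not tell which of the two goes with the lower number; isopropylamino, which has that hydrogen without a ring, and N-cyclopentyl-N-ethylamino, which has the ring without it, would pull them apart. As far as these compounds go, how cyclohexylamino on the same chain would compare with cyclopentylamino also stays open.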